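A few compounds are considered here, and "the series" means these few. Any claim that something is new, unique, unknown or untested is made for them only; others in the source may bear on it.

Measured so far in a functional assay on the whole organism (strain albino) for inhibition, with Rattus norvegicus as the target, read by paw edema, with stated times of 3 h and 1 h, at a dose of 100 mg/kg by the oral route; on this read-out higher numbers stand for more inhibition at the one dose given (going by the name of the read-out) and lower numbers for less inhibition:

compound 1 `Cc1cc(-c2ccc(Cl)cc2)n(-c2ccc(S(N)(=O)=O)cc2)n1`: 62.5%
compound 2 `Cc1cc(C)n(Cc2n[nH]c(=S)o2)n1`: 34.9%

Compound 2 gives the lower of the two numbers; compound 1 sits higher, and that gap is beyond the usual scatter. The two compounds differ in more than one place, so the gap is not tied to any single change. Next in line is compound 3 `Cc1cc(-c2ccccc2)n(Cc2n[nH]c(=S)o2)n1`, still to be measured in this assay. Relative to compound 2 the change is phenyl in place of methyl on an aromatic carbon. Within the data shown here, no single-site step between measured compounds is available to set the size of this change. Taken on its own, with compound 1 as the only other point, a modest upward step is expected, of the order of the gap between the two measured numbers or somewhat less. Compound 3 is expected to give about 46%, with the likely range from 30% to 62%, which means an expected step of a number 11.1 percentage points higher from compound 2 to compound 3 (beyond the scatter) in this assay.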

Compound 3, a percentage reported as inhibition, in the whole organism at one dose (the size of the read-out at that dose, not a potency): 48.7%
Estimate against measurement, compound 3: 2.7 percentage points below, within the range that was stated.
By their numbers in this assay, from the lowest: compound 2; then compound 3; then compound 1.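

In this assay, among these compounds, phenyl in place of methyl on the aromatic carbon next to the ring nitrogen gives a number 13.8 percentage points higher from compound 2 to compound 3 (beyond the scatter), the only single-place step available. This position therefore accepts a six-membered aromatic ring of carbon only without a loss of inhibition at the one dose given, so the methyl group is not required there for this read-out. Nothing on hand gives a cause for this rise.

Still open, from the compounds shown here alone, is how other groups behave at this carbon, for instance a cyclohexyl ring, a longer alkyl chain or an amine. Also open, going by these compounds, is whether the step carries over to the core of compound 1, which differs from compound 3 in more than one place and so allows no direct reading.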